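A Bridged Ring Swap at the Receptor

The source may hold more compounds than are shown below. What is called first, only, known or untested is meant among the compounds shown, and "the series" means these compounds.

Compound 1 `O=C(CCc1ccc(C(F)(F)F)cc1)Nc1ccc2nc(N3CCCC3)ccc2c1` and compound 2 `O=C(CCc1ccc(C(F)(F)F)cc1)Nc1ccc2nc(N3CC4CC3CO4)ccc2c1` share one core and differ only in the ring fixed to it. In an assay on isolated protein for displacement of a labelled ligand from melanin-concentrating hormone receptor 1 (Homo sapiens) (on this read-out lower numbers stand for stronger inhibition and higher numbers for weaker inhibition), compound 1 gives 3 nM; 3 nM (2 entries), while compound 2 gives 13 nM, the weaker of the two numbers shown. Compound 3 `O=C(CCc1ccc(C(F)(F)F)cc1)Nc1ccc2nc(N3CC4CCC3C4)ccc2c1` keeps the same core; its change from compound 2 is a group of 7 heavy atoms (6 carbon, 1 nitrogen; one five-membered non-aromatic ring of carbon only, one five-membered non-aromatic ring with 1 hetero atom) in place of a group of 7 heavy atoms (5 carbon, 1 nitrogen, 1 oxygen; 2 five-membered non-aromatic rings with 1 hetero atom each), on an aromatic carbon. Within the data shown here, no measured pair shows this kind of change, so only a modest step is expected, slightly toward stronger binding. Compound 3 is estimated at 6 nM in this assay, within 2 nM to 20 nM. The expected step is a 2.2-fold lower number from compound 2 to compound 3 (0.34 log units; beyond the scatter).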

Compound 3, half-maximal inhibitory concentration: 1 nM
Compound 3: middle estimate off by 6.0-fold (0.78 log units), on the high side; the measured number lies below the stated range.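

In this assay, the group at this place matters even when its size stays the same: both groups have 7 heavy atoms, yet the change to the group with a five-membered ring of carbon only gives a 13-fold lower number from compound 2 to compound 3 (1.11 log units; beyond the scatter). Nothing measured here gives the reason for this step. The compounds shown do not separate the loss of the oxygen from the change in how the rings are built. From the compounds shown here alone, how a morpholine or an open-chain diethylamino group would behave at this place also remains open.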